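The compounds below may be only part of what the source reports. "The series", "measured", "known", "first", "only" and "open" are said of these compounds alone.

Compound 1 `O=C1/C(=C/c2ccccc2Cl)Cc2ccccc21` was tested in a functional assay on CCRF-CEM cells (Homo sapiens) for inhibition (a higher number here means a weaker inhibitor, a lower number a stronger inhibitor), where compound 1 gives 57000 nM. That is the lower of the two numbers recorded so far; compound 2 `O=C1/C(=C/c2ccc(Cl)cc2Cl)CCCc2ccccc21` gives 407000 nM in this assay, a higher number, beyond the usual scatter. Compound 3 `O=C1/C(=C/c2ccccc2F)Cc2ccccc21` differs from compound 1 in one place: fluoro in place of chloro on an aromatic carbon, a fluoro in place of chloro on an aromatic carbon. For the measured compounds named here, no measured pair shows this exact swap, so the expectation rests on the change alone: a small move, if any, toward a higher number, likely within the scatter. The estimated result for compound 3 is 80000 nM, with a range of 30000 nM to 220000 nM, an expected step of a 1.4-fold higher number from compound 1 to compound 3 (0.15 log units; within the scatter).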

Compound 3, half-maximal inhibitory concentration: 47100 nM
Compound 3: the middle estimate sits 1.7-fold (0.23 log units) above what was measured, and the stated range covers the measured number.
By their numbers in this assay, from the lowest: compounds 3 and 1 (each within the scatter of the next); then compound 2.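

In this assay, fluoro in place of chloro on this aromatic carbon, ortho to a large group, gives a 1.2-fold lower number from compound 1 to compound 3 (0.08 log units; within the scatter) and that step lies within the scatter. This first single-place comparison therefore cannot tell the two halogens apart at this position. Nothing available explains the result.

The compounds shown leave open whether a different kind of group here, such as a methoxy group, an amine or a carboxylic acid, would shift the number beyond the scatter. They also leave open what plain hydrogen at this position would give.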